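Removing the Phenyl From the Ring Nitrogen

This account rests on a few compounds, and the source may have more. Where it says the series, first, only, none or still open, it means among the compounds named here.

Three compounds have been measured in a functional assay on the whole organism (plasma, strain albino) for inhibition, with Rattus norvegicus as the target, with stated times of 1 h and 4 h, at a dose of 25 mg/kg by the oral route; on this read-out lower numbers stand for a weaker effect and higher numbers for a stronger effect at the one dose given:

compound 1, `COc1ccc(C2CC(c3ccc(NC(=O)c4cc(Cl)ccc4OC)cc3)=NN2C)cc1`, gives 69.6%
compound 2, `COc1ccc(C2CC(c3ccc(NC(=O)c4cc(Cl)ccc4OC)cc3)=NN2c2ccccc2)cc1`, gives 82.3%
compound 3, `COc1ccc(Cl)cc1C(=O)Nc1ccc(C2=NN(c3ccccc3)C(c3ccc([N+](=O)[O-])cc3)C2)cc1`, gives 75.3%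

Compound 2 has the highest of the three numbers. Compound 3 is nearest, since a number 7 percentage points lower from compound 2 to compound 3 (within the scatter); compound 1 is furthest, since a number 12.7 percentage points higher from compound 1 to compound 2 (beyond the scatter).

The next compound is compound 4, `COc1ccc(C2CC(c3ccc(NC(=O)c4cc(Cl)ccc4OC)cc3)=NN2)cc1`. It differs from compound 2 in one place: hydrogen in place of phenyl on an amine nitrogen in a ring.

Going by the values given here, the step that bears on this is the one from compound 1 to compound 2, where a phenyl took the place of a methyl on the same ring nitrogen and a number 12.7 percentage points higher from compound 1 to compound 2 (beyond the scatter). Compound 4 moves the other way, from phenyl to something smaller still, so a drop of roughly that size is expected in this assay. The step from compound 2 to compound 4 is expected to be a number 17.3 percentage points lower from compound 2 to compound 4 (beyond the scatter). Compound 4 is therefore estimated at 65%, with a range from 50% to 80%.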

Compound 4, a percentage reported as inhibition, in the whole organism at one dose (the size of the read-out at that dose, not a potency): 70.6%
Estimate against measurement, compound 4: 5.6 percentage points below; the range from low to high includes it.
By their numbers in this assay, from the lowest: compounds 1, 4, 3 and 2 (each within the scatter of the next, the first and the last beyond it).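

Taking the phenyl off the ring nitrogen gives a number 11.7 percentage points lower from compound 2 to compound 4 (beyond the scatter) in this assay, so the higher number of compound 2 depends on that phenyl and is not kept when the nitrogen carries only hydrogen. Replacing the methyl with hydrogen gives a number 1 percentage points higher from compound 1 to compound 4 (within the scatter), so this assay does not separate these two small substituents, and among the three groups seen on this nitrogen only phenyl stands apart. Nothing available here explains why the phenyl makes this difference.

Going by these compounds, what a benzyl group, an acetyl group or a longer chain such as butyl would give on this nitrogen remains open, so it is unclear whether phenyl is unusual or merely one of many groups that would raise the number. Also open, on these data alone, is whether nitro in place of methoxy would behave the same way with hydrogen on the ring nitrogen.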